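Swapping the halogen on the side ring and Vero cytotoxicity

The source may report more compounds than this note shows. Statements on the series, on what has been measured and on what is new or still open speak of the compounds shown alone.

Measured compounds:
Compound 1 `N/C(=N/NC(CC(=O)c1ccc(-n2ccnc2)cc1)c1ccc(F)cc1)c1ccccn1` gives 78800 nM in an ADME assay on Vero cells (Chlorocebus sabaeus) for cytotoxicity, read by MTT assay, with a stated time of 72 h; a lower number here means that less compound is tolerated, a higher number that more compound is tolerated.
Compound 2 `N/C(=N/NC(CC(=O)c1ccc(-n2ccnc2)cc1)c1ccccc1)c1ccccn1` gives 63500 nM in this assay.
Compound 3 `N/C(=N/NC(CC(=O)c1ccc(-n2ccnc2)cc1)c1ccc(Br)cc1)c1ccccn1` gives 298000 nM in this assay.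

Compound 3 has the highest number of the three, so it is the best tolerated. Its nearest neighbour is compound 1, with a 3.8-fold higher number from compound 1 to compound 3 (0.58 log units; beyond the scatter); further away lies compound 2, with a 4.7-fold higher number from compound 2 to compound 3 (0.67 log units; beyond the scatter). Between compound 1 and compound 2 the step is a 1.2-fold lower number from compound 1 to compound 2 (0.09 log units; within the scatter), so fluoro and hydrogen at this place cannot be told apart here.

Compound 4 `N/C(=N/NC(CC(=O)c1ccc(-n2ccnc2)cc1)c1cccc(F)c1)c1ccccn1` is the next step. The change is 3-fluorophenyl in place of 4-bromophenyl on a saturated chain carbon bound to an amine nitrogen and a saturated chain carbon. Among the compounds with values here, none of the measured compounds carries a 3-fluorophenyl group, so the closest guide is the step from fluoro to bromo, which raised the number; taking bromo away again should undo most of that. The step is therefore expected to run downward, roughly a 3.7-fold lower number from compound 3 to compound 4 (0.57 log units; beyond the scatter). Compound 4 is estimated at 80000 nM, with a range from 40000 nM to 200000 nM.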

Compound 4, half-maximal cytotoxic concentration: 26500 nM
Compound 4: the middle estimate sits 3.0-fold (0.48 log units) above what was measured; measured number below the stated range.
By their numbers in this assay, from the lowest: compound 4; then compounds 2 and 1 (each within the scatter of the next); then compound 3.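

In this assay, the place of the fluoro group on the side ring matters, with a 3.0-fold lower number from compound 1 to compound 4 (0.47 log units; beyond the scatter), even though 3-fluorophenyl and 4-fluorophenyl have the same heavy-atom count. Fluoro also now separates from hydrogen, with a 2.4-fold lower number from compound 2 to compound 4 (0.38 log units; beyond the scatter), so adding fluoro need not leave the number unchanged, as it seemed to from the earlier pair; the widest gap in the set is now an 11-fold lower number from compound 3 to compound 4 (1.05 log units; beyond the scatter), which leaves compound 4 as the least tolerated of the four. Nothing available explains why moving the fluoro group lowers the number.

The compounds shown leave open whether bromo would respond to the same move as fluoro does. They also leave open where a chloro or methoxy group on the side ring would fall among these numbers.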